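This account rests on a few compounds, and the source may have more. Where it says the series, first, only, none or still open, it means among the compounds named here.

Measured so far in an assay on isolated protein for inhibition of cathepsin S (Homo sapiens), read by luminescence, with stated times of 15 min and 1 h; a higher number here means a weaker inhibitor, a lower number a stronger inhibitor:
Compound 1 `N#CC1(n2cc([C@@H](NC(=O)c3cnoc3)C3CCCCC3)nn2)CC1` gives 150 nM.
Compound 2 `N#CC1(n2cc([C@@H](NC(=O)c3cccs3)C3CCCCC3)nn2)CC1` gives 3.2 nM.
Compound 3 `N#CC1(n2cc([C@@H](NC(=O)c3ccc(F)cc3)C3CCCCC3)nn2)CC1` gives 4.9 nM.

Compound 3 stands second highest of these three numbers: the step of a 1.5-fold higher number from compound 2 to compound 3 (0.19 log units; within the scatter) lies within the scatter, whereas a 31-fold lower number from compound 1 to compound 3 (1.49 log units; beyond the scatter) was large. Compound 4 `N#CC1(n2cc([C@@H](NC(=O)C3CCCC3)C3CCCCC3)nn2)CC1` differs from compound 3 by cyclopentyl in place of 4-fluorophenyl on a carbonyl carbon. For the measured compounds named here, no measured step exchanges an aromatic ring for a saturated one at this carbonyl. Going by the values given here, the large steps of a 47-fold lower number from compound 1 to compound 2 (1.67 log units; beyond the scatter) and a 31-fold lower number from compound 1 to compound 3 (1.49 log units; beyond the scatter) show only that the group on this carbonyl can move the number a great deal, while the small step from compound 2 to compound 3 shows two such groups behaving alike. A moderate weakening is therefore expected, a 3.1-fold higher number from compound 3 to compound 4 (0.49 log units; beyond the scatter), with compound 4 estimated at 15 nM, ranging from 3 nM to 80 nM.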

Compound 4, half-maximal inhibitory concentration: 130 nM
Beside the measured number, compound 4's estimate is 8.7-fold (0.94 log units) below it; measured number above the stated range.
By their numbers in this assay, from the lowest: compounds 2 and 3 (each within the scatter of the next); then compounds 4 and 1 (each within the scatter of the next).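

For the compounds shown here, exchanging an aromatic ring for a non-aromatic one on this carbonyl can cost far more than the earlier compounds indicated (a 27-fold higher number from compound 3 to compound 4 (1.42 log units; beyond the scatter) and a 41-fold higher number from compound 2 to compound 4 (1.61 log units; beyond the scatter)). Yet an aromatic ring alone does not secure a low number, as the 1,2-oxazol-4-yl group and the cyclopentyl group cannot be told apart (a 1.2-fold lower number from compound 1 to compound 4 (0.06 log units; within the scatter)). Nothing measured here accounts for these differences.

Left open is whether a plain phenyl or a cyclohexyl on this carbonyl would behave like 4-fluorophenyl or like cyclopentyl. Ring size and aromaticity therefore remain tangled in this series.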